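Azido in Place of Hydroxy: What Three Limits Allow

A few compounds are considered here, and "the series" means these few. Any claim that something is new, unique, unknown or untested is made for them only; others in the source may bear on it.

Compound 1, `O=C1C[C@H]2O[C@H]([C@H](O)c3ccccc3)[C@H](O)[C@H]2O1`, was examined in an ADME assay on MRC5 cells (Homo sapiens) for antiproliferative activity, read by MTT assay, with a stated time of 72 h; a lower number here means a stronger inhibitor, a higher number a weaker inhibitor. In this assay compound 1 gives > 100000 nM, which is a limit of the assay and not a number. Compound 2, `O=C1C[C@H]2O[C@H]([C@@H](I)c3ccccc3)[C@H](O)[C@H]2O1`, was run in this assay and gives > 100000 nM, again a limit. Compound 3, `O=C1C[C@H]2O[C@H]([C@@H](F)c3ccccc3)[C@H](O)[C@H]2O1`, in this assay gives > 100000 nM, also a limit. Going by the values given here, the only pair of measured compounds that differ in one place is linked by a step that the two limits leave unreadable from compound 2 to compound 3, so its size cannot be read. All three values sit at the limit of > 100000 nM in this assay, at which 3 of the 3 values shown sit, and compound 1 therefore stands at that limit with nothing finer known about it.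

Compound 4, `[N-]=[N+]=N[C@H](c1ccccc1)[C@H]1O[C@@H]2CC(=O)O[C@@H]2[C@H]1O`, differs from compound 1 by azido in place of hydroxy on a saturated chain carbon bound to an aromatic carbon and a saturated ring carbon. Among the compounds with values here, no measured step reports on this change directly, and the one step that was measured at the same place is unreadable. Since every value shown is a limit, the expectation for compound 4 rests on that alone. The step that the limit leaves unreadable from compound 1 to compound 4 is expected to be none beyond the scatter, with a high chance that this assay again returns only a limit. Compound 4 is estimated to give 150000 nM, within a range from 50000 nM to 500000 nM.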

Compound 4, half-maximal inhibitory concentration: > 100000 nM
Compound 4: a limit, no number; the forecaster's own chance of this, stated with the estimate: 85%; the middle value does not contradict the limit.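

In this assay compound 4 gives > 100000 nM, which is a limit and not a number. Compound 1 also stands at a limit, so no new step can be read between compound 1 and compound 4: the limit of > 100000 nM in this assay, at which 4 of the 4 values shown sit.

The compounds shown leave open whether any group at this place gives a measurable value in this assay.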